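Working notes: from compound 2 to compound 3

This account rests on a few compounds, and the source may have more. Where it says the series, first, only, none or still open, it means among the compounds named here.

In an ADME assay on SH-SY5Y cells (Homo sapiens) for cytotoxicity, read by MTT assay, with a stated time of 48 h (a lower number here means that less compound is needed, a higher number that more compound is needed for the effect), compound 1 (`O=C(O)c1ccccc1-c1ccccc1C(=O)NCCCCCCCn1cc(-c2cccnc2)nn1`) reads > 500 nM, which is a limit of the assay and not a number. Within the data shown here, compound 2 (`O=C(NCCCCCCCn1cc(-c2cccnc2)nn1)c1ccccc1-c1c[nH]nn1`) gives 86.5 nM, the only actual number so far. Compound 3 (`O=C(NCCCCCCCn1cc(-c2cccnc2)nn1)c1ccccc1-n1cc(CN2CCCCC2)nn1`) carries 4-((piperidin-1-yl)methyl)-1H-1,2,3-triazol-1-yl in place of 1H-1,2,3-triazol-4-yl on an aromatic carbon. Among the measured compounds shown here, the one measured step that bears on this is an at least 5.7-fold lower number from compound 1 to compound 2 (0.76 log units; beyond the scatter), a different exchange, also on an aromatic carbon. Its size is only a bound, since compound 1 sits at the limit of > 500 nM in this assay, at which 1 of the 2 values shown sits. That step shows that the number in this assay can move with the group at this place, but it sets no direction for the new exchange. The expected change, with no direction favoured and nothing beyond the scatter, is a 1.2-fold higher number from compound 2 to compound 3 (0.06 log units; within the scatter). Compound 3 is estimated at 100 nM, with an expected range of 30 nM to 400 nM.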

Compound 3, half-maximal effective concentration: > 500 nM
Compound 3 was reported as a limit; the forecaster's own chance of this, stated with the estimate: 15%; middle value at least 5.0-fold (0.69 log units) from the limit.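

In this assay, placing 4-((piperidin-1-yl)methyl)-1H-1,2,3-triazol-1-yl at this place gives an at least 5.7-fold higher number from compound 2 to compound 3 (0.76 log units; beyond the scatter). A five-membered aromatic ring with 3 hetero atoms at this place is therefore not enough on its own to hold the lower number, since compound 2 and compound 3 both carry one. The step between compound 1 and compound 3 cannot be read, since both are reported only as limits of the assay: the limit of > 500 nM in this assay, at which 2 of the 3 values shown sit.

From the compounds shown here alone, this exchange alters the point of attachment of the triazole and adds the piperidin-1-ylmethyl group together, so the share of each in the step remains open. An unsubstituted 1H-1,2,3-triazol-1-yl, or a 1H-1,2,3-triazol-4-yl carrying a piperidin-1-ylmethyl group, would separate the two.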